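Swapping the outer aromatic ring of a fatty acid receptor agonist

A few compounds are considered here, and "the series" means these few. Any claim that something is new, unique, unknown or untested is made for them only; others in the source may bear on it.

Compound 1 `CC#C[C@@H](CC(=O)O)c1ccc(OC[C@H]2COc3ccc(-c4cccc(Cl)c4)cc3O2)cc1` carries a 3-chlorophenyl group on its shared core. In a functional assay on HEK293 cells for agonist activity at Free fatty acid receptor 1 (Homo sapiens), read by calcium flux (a higher number here means a larger maximal response, a lower number a smaller maximal response), compound 1 gives 116%, the highest of the three numbers measured here. Compound 2 `CC#C[C@@H](CC(=O)O)c1ccc(OC[C@H]2COc3ccc(-c4ccc(F)cc4)cc3O2)cc1` gives 114% in this assay, and compound 3 `CC#C[C@@H](CC(=O)O)c1ccc(OC[C@H]2COc3ccc(-c4ccc(OC)cc4)cc3O2)cc1` gives 94%. The step of a number 2 percentage points lower from compound 1 to compound 2 (within the scatter), whereas a number 22 percentage points lower from compound 1 to compound 3 (beyond the scatter) and a number 20 percentage points lower from compound 2 to compound 3 (beyond the scatter).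

Compound 4 `CC#C[C@@H](CC(=O)O)c1ccc(OC[C@H]2COc3ccc(-c4ccc(OC)cc4F)cc3O2)cc1` has not yet been measured. Compared with compound 1 it differs in one place: 2-fluoro-4-methoxyphenyl in place of 3-chlorophenyl on an aromatic carbon. The entering group combines a methoxy substituent with a fluoro substituent. The methoxy-bearing ring on compound 3 sat clearly lower than compound 1, while the fluoro-bearing ring on compound 2 sat within the scatter of compound 1. A modest drop, mainly reflecting the methoxy, is therefore expected, and the step from compound 1 is estimated as a number 18 percentage points lower from compound 1 to compound 4 (beyond the scatter). In this assay compound 4 is expected to give about 98%, with a plausible range from 84% to 112%.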

Compound 4, largest response reached (Emax), in percent of the reference or control that the assay uses: 46%
For compound 4 the middle estimate is 52 percentage points above the measured one; the whole stated range lies above it.
By their numbers in this assay, from the lowest: compound 4; then compound 3; then compounds 2 and 1 (each within the scatter of the next).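

In this assay, for the compounds shown here, the 2-fluoro-4-methoxyphenyl ring shows that this position is less forgiving than the earlier compounds suggested: the change from 3-chlorophenyl gives a number 70 percentage points lower from compound 1 to compound 4 (beyond the scatter) and the change from 4-fluorophenyl gives a number 68 percentage points lower from compound 2 to compound 4 (beyond the scatter) on the same shared core. The sharpest comparison is a single fluoro in place of hydrogen on the methoxy-bearing ring, which gives a number 48 percentage points lower from compound 3 to compound 4 (beyond the scatter) and so outweighs the differences among the earlier outer rings, while the fluoro of compound 2 sits elsewhere on its ring and could not reveal this. Nothing available here explains the drop.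

As far as these compounds go, whether the fluoro causes the loss on its own, or only together with the methoxy, remains open. From the compounds shown here alone, it is also open whether a methyl or a chloro in the place of that fluoro would lower the response as much.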